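A few compounds are considered here, and "the series" means these few. Any claim that something is new, unique, unknown or untested is made for them only; others in the source may bear on it.

Three compounds were measured in a functional assay on HeLa cells (Homo sapiens) for cytotoxicity, read by MTT assay, with a stated time of 72 h, tested at 10 uM; on this read-out lower numbers stand for less inhibition of growth and higher numbers for more inhibition of growth at the one concentration tested. Compound 1, with the structure `Cc1ccnc(/C(N)=N/NC(=S)N2CCN(c3ccccn3)CC2)c1`, gives 49.2%. Compound 2, with the structure `Cc1cccc(/C(N)=N/NC(=S)N2CCCC2)n1`, gives 79.2%. Compound 3, with the structure `N/C(=N\NC(=S)N1CCCC1)c1ccccn1`, gives 63.5%. Of the three numbers, compound 1 stands lowest; its steps to compound 3 and to compound 2 are both beyond the scatter.

Compounds 2 and 3 differ in one place only, namely (hydrogen in place of methyl on an aromatic carbon). That change produced a number 15.7 percentage points lower from compound 2 to compound 3 (beyond the scatter), a modest step beyond the scatter. Compound 1 and compound 2 differ in more than one place, and the difference between their two cores is not broken down here.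

Compound 4, with the structure `N/C(=N\NC(=S)N1CCN(c2ccccn2)CC1)c1ccccn1`, has not yet been measured. It differs from compound 1 by hydrogen in place of methyl on an aromatic carbon. Within the data shown here, this is the same kind of change as the one from compound 2 to compound 3, but not the same: in compound 2 the methyl sits next to the ring nitrogen, whereas in compound 1 it sits opposite the ring nitrogen, both being meta to a large group. Among the measured compounds shown here, the step from compound 1 to compound 4 is therefore expected to be similar in direction, namely a number 12.2 percentage points lower from compound 1 to compound 4 (beyond the scatter), resting on the single measured example in which compound 2 went to compound 3 by a number 15.7 percentage points lower from compound 2 to compound 3 (beyond the scatter). For the measured compounds named here, the place of the methyl differs between the two cases, and only one such step is known. The range is set wide for that reason. For compound 4 in this assay the expected number is 37%, between 22% and 55%.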

Compound 4, percent growth inhibition at one concentration: 56.1%
The estimate for compound 4 lay 19.1 percentage points below the measured number, and the stated range ends below it.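

In this assay, among these compounds, the change from 4-methylpyridin-2-yl to pyridin-2-yl on the core of compound 1 gives a number 6.9 percentage points higher from compound 1 to compound 4 (within the scatter), so on this core the swap produces no step that can be told apart from ordinary repeat variation. Among the compounds shown here, the swap therefore does not carry over as a fixed step from one core to the other: the same change on two cores in this assay, a number 15.7 percentage points lower (beyond the scatter) from compound 2 to compound 3 and a number 6.9 percentage points higher (within the scatter) from compound 1 to compound 4, 22.6 percentage points apart, beyond the scatter of two such steps With only two pairs, this does not show what sets the two steps apart, whether the place of the methyl, which in compound 1 is opposite the ring nitrogen, or some other difference between the two cores, and it gives no rule for predicting the step on a third core.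

The compounds shown carry only methyl or hydrogen on this ring, which leaves open how a different group, such as ethyl, methoxy, chlorine or an amine, would behave on either core. Also open, on these data alone, is whether moving the methyl to another place on one unchanged core would alter the growth inhibition, and whether the picture would hold at concentrations other than the single one tested.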